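Chloro for methoxy on the acid-bearing ring

This account rests on a few compounds, and the source may have more. Where it says the series, first, only, none or still open, it means among the compounds named here.

Of the compounds shown here, three share one core and have been measured in an assay on HEK293 cells for positive allosteric modulation of metabotropic glutamate receptor 3 (Rattus norvegicus), read by thallium flux, with a stated time of 2.5 min; a higher number here means a larger maximal response, a lower number a smaller maximal response. Compound 1 `COc1cc(C(=O)O)ccc1OCCCCOc1ccc(C(=O)C(C)C)c(O)c1C` gives 25.6% in this assay. Compound 2 `COC(=O)c1ccc(OCCCCOc2ccc(C(=O)CC3CCCC3)c(O)c2C)cc1` gives 22% in this assay. Going by the values given here, compound 3 `COc1cc(C(=O)O)ccc1OCCCCOc1ccc(C(=O)CC(C)C)c(O)c1C` gives 73.9% in this assay, the highest of the three numbers; its nearest neighbour is compound 1, and the only single-change step recorded, a number 48.3 percentage points higher from compound 1 to compound 3 (beyond the scatter), concerns isobutyl in place of isopropyl on a carbonyl carbon. Compound 4 `Cc1c(OCCCCOc2ccc(C(=O)O)cc2Cl)ccc(C(=O)CC(C)C)c1O` has not been measured yet and differs from compound 3 in one place: chloro in place of methoxy on an aromatic carbon. Among the compounds with values here, no measured step bears on this change; the one recorded step touches a different part of the molecule, and compound 2 differs from the others in more than one place. With nothing to point in either direction, the writer expects for compound 4 a step of a number 8.9 percentage points lower from compound 3 to compound 4 (within the scatter) in this assay, which is not beyond the scatter. Compound 4 is therefore estimated at 65%, with a range from 40% to 90%.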

Compound 4, largest response reached (reported as percent of maximum), in percent of the reference or control that the assay uses: 62.9%
Estimate against measurement, compound 4: 2.1 percentage points above; low and high end bracket the measured number.
By their numbers in this assay, from the lowest: compounds 2 and 1 (each within the scatter of the next); then compound 4; then compound 3.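

In this assay, the position on the aromatic carbon ortho to a large group and meta to a carboxy group proves sensitive to this change: chloro in place of methoxy gives a number 11 percentage points lower from compound 3 to compound 4 (beyond the scatter). Methoxy is therefore not needed here for a sizeable maximal response, since compound 4, with chloro, still gives 62.9%, and this step is much smaller than the earlier a number 48.3 percentage points higher from compound 1 to compound 3 (beyond the scatter) at the carbonyl carbon. Nothing measured on these compounds accounts for the drop.

The compounds shown leave open whether a smaller group such as fluoro, or a methyl or ethoxy group, at this carbon would give a response closer to that of compound 3. From the compounds shown here alone, it also remains open whether the step would keep its size with isopropyl in place of isobutyl on the carbonyl carbon.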